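The source may report more compounds than this note shows. Statements on the series, on what has been measured and on what is new or still open speak of the compounds shown alone.

Compound 2 `C=CCOc1nc(N)nc2c1ncn2/C=C1/C[C@@H]1CO` has, in a functional assay on HFF cells (Homo sapiens) for cytotoxicity (on this read-out lower numbers stand for higher toxicity in this test and higher numbers for lower toxicity in this test), the highest number of the two measured compounds: compound 2 gives 220000 nM, whereas compound 1 `CCCCCOc1nc(N)nc2c1ncn2/C=C1/C[C@@H]1CO` gives 41900 nM. Compound 3 `CCCOc1nc(N)nc2c1ncn2/C=C1/C[C@@H]1CO` differs from compound 2 by ethyl in place of vinyl on a saturated chain carbon bound to an oxygen on an aromatic ring. Within the data shown here, the only measured step that bears on this change is a 5.3-fold higher number from compound 1 to compound 2 (0.72 log units; beyond the scatter), and there the group entering was butyl rather than ethyl, so it is only a rough guide. Exchanging vinyl for ethyl is expected to move the number less, giving an expected step of a 1.5-fold lower number from compound 2 to compound 3 (0.17 log units; within the scatter). Compound 3 is therefore estimated at 150000 nM, within a range from 50000 nM to 400000 nM.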

Compound 3, half-maximal cytotoxic concentration: 69400 nM
Compound 3: middle estimate off by 2.2-fold (0.33 log units), on the high side; the range from low to high includes it.
By their numbers in this assay, from the lowest: compounds 1 and 3 (each within the scatter of the next); then compound 2.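

In this assay the change from allyl to propyl keeps the heavy atom count the same and removes only the double bond, yet it gives a step beyond the scatter (a 3.2-fold lower number from compound 2 to compound 3 (0.50 log units; beyond the scatter)). The step that shortens the chain stays within the scatter (a 1.7-fold higher number from compound 1 to compound 3 (0.22 log units; within the scatter)), so compound 1 and compound 3 cannot be told apart on this read-out. No measurement here explains the difference between allyl and propyl. From the compounds shown here alone, whether a propargyl group, with a triple bond, a branched chain or an amine at this place would match compound 2 remains open.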